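The compounds below may be only part of what the source reports. "The series", "measured", "known", "first", "only" and "open" are said of these compounds alone.

Cytotoxicity in an ADME assay on LLC-MK2 cells (Macaca mulatta) for cytotoxicity, read by spectrophotometry and crystal violet staining, with a stated time of 4 days (a higher number here means that more compound is tolerated, a lower number that less compound is tolerated), is followed across a series built on the shared core of compound 1 `CC(C)n1ncc2c(C(=O)Nc3ccccn3)cc(-c3ccsc3)nc21`, which gives 25000 nM. Compound 2 `CC(C)n1ncc2c(C(=O)Nc3ccncc3)cc(-c3cccs3)nc21` gives 6300 nM in this assay, the lowest of the two numbers shown; compound 1 stands above it by a gap beyond the scatter. For compound 3 `CC(C)n1ncc2c(C(=O)Nc3ccc(F)cc3)cc(-c3ccco3)nc21` the this assay reports only a limit, > 200000 nM, and no number. Compound 4 `CC(C)n1ncc2c(C(=O)Nc3ccc(F)cn3)cc(-c3cccs3)nc21` is not yet measured; it differs from compound 2 by 5-fluoropyridin-2-yl in place of pyridin-4-yl on an amide-type nitrogen. Among the measured compounds shown here, no measured pair shows this change alone, so the direction rests on the two numbers available: compound 1 gives 25000 nM and compound 2 gives 6300 nM, while differing in two places. A moderate rise in the tolerated concentration is expected, a 3.2-fold higher number from compound 2 to compound 4 (0.50 log units; beyond the scatter). Compound 4 is estimated at 20000 nM, between 6000 nM and 80000 nM.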

Compound 4, half-maximal cytotoxic concentration: > 200000 nM
Compound 4 was reported as a limit; the forecaster's own chance of this, stated with the estimate: 15%; middle value at least 10-fold (1.00 log units) away from the limit.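

In this assay, among the compounds shown here, 5-fluoropyridin-2-yl in place of pyridin-4-yl on an amide-type nitrogen gives the first comparison that differs in one place: an at least 31-fold higher number from compound 2 to compound 4 (1.50 log units; beyond the scatter). For compound 4, > 200000 nM is a limit and not a number. The step therefore fixes only a minimum size: the limit of > 200000 nM in this assay, at which 2 of the 4 values shown sit.

From the compounds shown here alone, the change brings in a fluorine and also a different pyridine attachment, and which of the two carries the step stays open. Going by these compounds, how a chlorine atom or a methoxy group in place of that fluorine would read also stays open.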